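The compounds below may be only part of what the source reports. "The series", "measured", "known", "first", "only" and "open" are said of these compounds alone.

Of the compounds shown here, three that share one core have been measured in a functional assay on HCT-116 cells (Homo sapiens), read by MTT assay, with a stated time of 72 h; on this read-out lower numbers stand for stronger inhibition and higher numbers for weaker inhibition. Compound 1 `COc1ncnc2c1c(-c1cc3ccccc3o1)cn2[C@@H]1O[C@H](CO)[C@@H](O)[C@H]1O` gives 13800 nM. Compound 2 `CNc1ncnc2c1c(-c1cc3ccccc3o1)cn2[C@@H]1O[C@H](CO)[C@@H](O)[C@H]1O` reports only a limit, > 20000 nM. Compound 3 `CN(C)c1ncnc2c1c(-c1ccsc1)cn2[C@@H]1O[C@H](CO)[C@@H](O)[C@H]1O` also reports only a limit, > 20000 nM. Compound 3 therefore has no number of its own and sits at the limit of > 20000 nM in this assay, at which 2 of the 3 values shown sit.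

Compound 4 `CN(C)c1ncnc2c1c(-c1cc3ccccc3o1)cn2[C@@H]1O[C@H](CO)[C@@H](O)[C@H]1O` differs from compound 3 at one place, with 1-benzofuran-2-yl in place of thiophen-3-yl on an aromatic carbon.

Going by the values given here, no measured step shows this exchange directly. Among the compounds with values here, the only measured step, an at least 1.4-fold higher number from compound 1 to compound 2 (0.16 log units; that floor lies within the scatter), concerns a different change, methylamino in place of methoxy on an aromatic carbon, and its floor lies within the scatter. It does show that the 1-benzofuran-2-yl group occurs in compound 2 at the limit, so that group alone does not bring a value below the limit. Compound 1, with the same group, has a measured value not far under the limit.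

No step beyond the scatter is therefore expected in this assay, and no direction can be favoured; the expected step is a number no higher from compound 3 to compound 4 (the limit leaves the size open). Compound 4 is estimated at 20000 nM, with an expected range of 9000 nM to 40000 nM. It may well report only a limit.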

Compound 4, half-maximal inhibitory concentration: > 20000 nM
Compound 4 gave a limit, no number; the forecaster's own chance of this, stated with the estimate: 65%; the middle value lies on the limit itself.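

In this assay, 1-benzofuran-2-yl in place of thiophen-3-yl on this aromatic carbon, with the dimethylamino group kept, leaves compound 4 with a limit and no number, so the change brings no measurable value into view here, and the steps to compound 4 from compound 3 and from compound 2 cannot be read. Going by these compounds alone, the only readable new step is an at least 1.4-fold higher number from compound 1 to compound 4 (0.16 log units; that floor lies within the scatter), for dimethylamino in place of methoxy on an aromatic carbon, and it gives no firm evidence of a change at that site. With 1-benzofuran-2-yl now seen at the limit alongside both methylamino and dimethylamino, and only the methoxy compound carrying a number, the series gathers at one ceiling: the limit of > 20000 nM in this assay, at which 3 of the 4 values shown sit.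

Going by these compounds, how far compound 3 and compound 4 lie past their limits stays open, so thiophen-3-yl and 1-benzofuran-2-yl cannot be ranked against each other in this assay. Also open, on these data alone, is what a phenyl or pyridin-3-yl group would give at this position, and whether methoxy would still give a number with thiophen-3-yl in place of 1-benzofuran-2-yl.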